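Dichloropurines bearing a chloromethylbenzyl group: notes toward compound 3

A few compounds are considered here, and "the series" means these few. Any claim that something is new, unique, unknown or untested is made for them only; others in the source may bear on it.

Going by the values given here, compound 1 `ClCc1cccc(Cn2cnc3nc(Cl)nc(Cl)c32)c1` is the one member of the series with a number so far: in a functional assay on DU-145 cells (Homo sapiens) for cytotoxicity, read by sulforhodamine B assay, with a stated time of 48 h (on this read-out higher numbers stand for weaker inhibition of growth and lower numbers for stronger inhibition of growth), compound 1 gives 260 nM. Compound 2 `ClCc1ccc(Cn2cnc3ncnc(Cl)c32)cc1` carries a single chloro substituent on the shared core and was taken into the same assay, but in this assay compound 2 gives "not determined" (no result reported), so it stands on no number at all. Compound 3 `ClCc1ccc(Cn2cnc3nc(Cl)nc(Cl)c32)cc1` is the next point; the change from compound 2 to compound 3 is chloro in place of hydrogen on an aromatic carbon. With compound 2 undetermined, no size can be set for the step from compound 2 to compound 3 in this assay, and any direction assigned to it would rest on nothing measured. Compound 3 is therefore expected to land close to compound 1, because compound 1 gives 260 nM with the same two chloro groups on the core; compound 3 is estimated at 300 nM, within 100 nM to 1000 nM.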

Compound 3, concentration for total growth inhibition: 3460 nM
The estimate for compound 3 lay 12-fold (1.06 log units) below the measured number; the measured number lies above the stated range.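

Going by these compounds alone, compound 2 carries no number, so no step from compound 2 to compound 3 can be read. The compounds shown leave open what chloro in place of hydrogen on that aromatic carbon does to growth inhibition. No measured evidence bears on the result for compound 3.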